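A few compounds are considered here, and "the series" means these few. Any claim that something is new, unique, unknown or untested is made for them only; others in the source may bear on it.

Of the compounds shown here, two with a shared core have been measured in an assay on HEK293 cells for displacement of a labelled ligand from metabotropic glutamate receptor 5 (Rattus norvegicus), read by scintillation counting; on this read-out higher numbers stand for weaker inhibition and lower numbers for stronger inhibition. Compound 1 `Cc1nc(C#Cc2cc(C#N)cc([N+](=O)[O-])c2)cs1` gives 0.36 nM in this assay, and compound 2 `Cc1nc(C#Cc2cc(Br)cc(C#N)c2)cs1` gives 0.106 nM. Compound 2 has the lower of the two numbers, and the step of a 3.4-fold lower number from compound 1 to compound 2 (0.53 log units; beyond the scatter) separates it from compound 1. Compound 3 `Cc1nc(C#Cc2cc(Br)cc(Br)c2)cs1` has not yet been measured. It differs from compound 2 in one place: bromo in place of cyano on an aromatic carbon. Among the compounds with values here, no measured step swaps a cyano for a bromo, so none bears on this change directly. Within the data shown here, the one step that is known, a 3.4-fold lower number from compound 1 to compound 2 (0.53 log units; beyond the scatter), shows that a bromo entering the shared core in place of another group went along with a modestly lower number, but the group it replaced there was nitro, not cyano. With no closer guide, compound 3 is expected to show a step of a 1.9-fold higher number from compound 2 to compound 3 (0.28 log units; within the scatter) that may well stay within the usual scatter. The estimate for compound 3 in this assay is 0.2 nM, with a range from 0.06 nM to 0.7 nM.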

Compound 3, inhibition constant: 0.69 nM
Estimate against measurement, compound 3: 3.5-fold (0.54 log units) below; low and high end bracket the measured number.
By their numbers in this assay, from the lowest: compound 2; then compounds 1 and 3 (each within the scatter of the next).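

Bromo does not go with a lower number wherever it enters the shared core. In this assay, bromo in place of nitro gave a 3.4-fold lower number from compound 1 to compound 2 (0.53 log units; beyond the scatter), but bromo in place of cyano gives a 6.5-fold higher number from compound 2 to compound 3 (0.81 log units; beyond the scatter), so the same incoming group moves the number in opposite directions depending on which group leaves. Among these compounds, the lowest number therefore belongs to compound 2, which carries one bromo and one cyano, and replacing that cyano shows that it cannot be exchanged for a second bromo without a clear change in the read-out. Nothing measured here explains why the swap has this effect.

From the compounds shown here alone, it remains open whether the low number depends on the cyano group in particular, or whether other groups on this aromatic carbon, such as a chloro, a methoxy, an amine or a carboxylic acid, would give a similar number. The three compounds also cannot show how a plain hydrogen at this place would compare, which would reveal how much any substituent there matters at all.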